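This account rests on a few compounds, and the source may have more. Where it says the series, first, only, none or still open, it means among the compounds named here.

Compound 2 `O=c1ccoc2cc(OCc3cn(Cc4ccccc4Cl)nn3)ccc12` is one of two compounds already tested in an ADME assay on L02 cells (Homo sapiens) for cytotoxicity, read by MTT assay, with a stated time of 48 h; a higher number here means a weaker inhibitor, a lower number a stronger inhibitor. In this assay compound 2 gives only a limit, > 300000 nM. Its companion, compound 1 `Cc1ccc(Cn2cc(COc3ccc4c(=O)ccoc4c3)nn2)cc1`, likewise gives only a limit in this assay, > 300000 nM. The change between them, 2-chlorophenyl in place of 4-methylphenyl on a saturated chain carbon bound to an aromatic nitrogen, yields a step that the two limits leave unreadable from compound 1 to compound 2, because the limit of > 300000 nM in this assay, at which 2 of the 2 values shown sit, caps both values.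

Compound 3 `COc1ccc(Cn2cc(COc3ccc4c(=O)ccoc4c3)nn2)cc1` differs from compound 2 by 4-methoxyphenyl in place of 2-chlorophenyl on a saturated chain carbon bound to an aromatic nitrogen. Going by the values given here, the only measured step that bears on this change is a step that the two limits leave unreadable from compound 1 to compound 2, which gives no size. With both known values sitting at the limit, no direction can be read, and a benzyl swap of this kind is expected to leave the result near the limit again. Compound 3 is therefore estimated to show a step that the limit leaves unreadable from compound 2 to compound 3, landing at 400000 nM with a range from 150000 nM to 1200000 nM.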

Compound 3, half-maximal inhibitory concentration: > 300000 nM
Compound 3 gave a limit, no number (the forecaster's own chance of this, stated with the estimate: 80%); the middle value lies beyond the limit too.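

Going by these compounds alone, no step among compound 1, compound 2 and compound 3 can be read, since each gives only a limit in this assay: the limit of > 300000 nM in this assay, at which 3 of the 3 values shown sit. The compounds shown leave open how far apart the three actually lie, and whether any change to the shared core would give a measurable value.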